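The source may report more compounds than this note shows. Statements on the series, on what has been measured and on what is new or still open speak of the compounds shown alone.

Compound 1, `COc1ccc(CNC(=O)c2nc(-c3ccc(F)cc3)n(CC[C@@H](O)C[C@@H](O)CC(=O)O)c2C2CC2)cc1`: 1.2 nM
Compound 2, `CC(C)c1c(C(=O)NCc2ccccc2)nc(-c2ccc(F)cc2)n1CC[C@@H](O)C[C@@H](O)CC(=O)O`: 7.9 nM
Compound 3, `CCc1c(C(=O)NCc2ccccc2)nc(-c2ccc(F)cc2)n1CC[C@@H](O)C[C@@H](O)CC(=O)O`: 123 nM

All three were tested in an assay on microsomes from liver for inhibition of 3-hydroxy-3-methylglutaryl-coenzyme A reductase (Rattus norvegicus), read by scintillation counting, with stated times of 0.5 h and 0.75 h; a lower number here means a stronger inhibitor, a higher number a weaker inhibitor. Compound 1 gives the lowest number of the three: compound 2 sits higher, and compound 3 higher still, both gaps beyond the usual scatter. Among the compounds with values here, the only single-point step among the measured compounds is a 16-fold higher number from compound 2 to compound 3 (1.19 log units; beyond the scatter), a large weakening that concerns the group on the shared core, not the benzyl amide end.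

Compound 4, `O=C(O)C[C@H](O)C[C@H](O)CCn1c(-c2ccc(F)cc2)nc(C(=O)NCc2ccc(F)cc2)c1C1CC1`, has not yet been measured. It differs from compound 1 in one place: fluoro in place of methoxy on an aromatic carbon. Within the data shown here, no measured step reports this exchange, so no direct precedent exists. Compound 1 and compound 2 differ in two places at once, one of them at the same aromatic ring, and their values show only a moderate gap, which suggests the benzyl amide end tolerates a change there without collapse. On that basis compound 4 is expected to stay close to compound 1, with a 1.7-fold higher number from compound 1 to compound 4 (0.22 log units; within the scatter) as the estimated step, a shift no larger than the scatter or slightly weakening. The estimated value for compound 4 in this assay is 2 nM, within a range from 0.6 nM to 6.5 nM.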

Compound 4, half-maximal inhibitory concentration: 3.4 nM
For compound 4 the middle estimate is 1.7-fold (0.23 log units) below the measured one; measured number inside the range.
By their numbers in this assay, from the lowest: compound 1; then compound 4; then compound 2; then compound 3.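

Within the data shown here, replacing 4-methoxybenzyl with 4-fluorobenzyl on the amide gives the first direct reading at this position: in this assay the exchange produces a 2.8-fold higher number from compound 1 to compound 4 (0.45 log units; beyond the scatter) and counts as a modest weakening. Methoxy leaves with its hydrogen-bond acceptor and fluoro enters with none, yet the step is much smaller than a 16-fold higher number from compound 2 to compound 3 (1.19 log units; beyond the scatter) at the group on the shared core, so this para position gives up some strength on this exchange without a collapse. Nothing measured on these compounds indicates what lies behind the shift.

Going by these compounds, whether chloro, trifluoromethyl or an amine at this aromatic carbon would sit closer to compound 1 or to compound 4 stays open, so a single exchange cannot show a trend across groups. Compound 2 carries a plain benzyl but also differs from compound 1 in a second place, which leaves the effect of having no group on this ring unread for the core of compound 1.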